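Replacing an ester-bearing group with chloromethyl on a shared coumarin-type core

The source may hold more compounds than are shown below. What is called first, only, known or untested is meant among the compounds shown, and "the series" means these compounds.

Of the compounds shown here, two on a shared core have been measured so far. Compound 1 `CCOC(=O)COc1cc(=O)oc2cc(OCc3cccc(Cl)c3)ccc12` gives 0% in an assay on isolated protein (strain Sprague-Dawley) for inhibition of Amine oxidase [flavin-containing] A (Rattus norvegicus), read by spectrophotometry, with a stated time of 5 min, tested at 10 uM; on this read-out lower numbers stand for less inhibition and higher numbers for more inhibition at the one concentration tested (going by the name of the read-out). Within the data shown here, compound 2 `CCOC(=O)Nc1cc(=O)oc2cc(OCc3cccc(Cl)c3)ccc12` gives 21% in this assay, and the single step of a number 21 percentage points higher from compound 1 to compound 2 (beyond the scatter) places compound 2 highest of the two numbers, with compound 1 as its nearest neighbour.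

Compound 3 `O=c1cc(CCl)c2ccc(OCc3cccc(Cl)c3)cc2o1` has not yet been measured. Its change from compound 2 is chloromethyl in place of (ethoxycarbonyl)amino on an aromatic carbon, the incoming chloromethyl group being much smaller than the group it replaces and carrying no hydrogen-bond donor or acceptor. Among the measured compounds shown here, no measured step shows a chloromethyl group, so the one known step, which swapped (ethoxycarbonyl)methoxy for (ethoxycarbonyl)amino, bears only loosely on this change. Both measured numbers are low, so a small step is expected, in either direction or none beyond the scatter; the expected step is a number 6 percentage points lower from compound 2 to compound 3 (within the scatter). For compound 3 the estimated value in this assay is 15%, with a range from 0% to 45%.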

Compound 3, a percentage reported as inhibition, at one concentration (the size of the read-out at that concentration, not a potency): 21%
For compound 3 the middle estimate is 6 percentage points below the measured one, within the range that was stated.
By their numbers in this assay, from the lowest: compound 1; then compounds 2 and 3 (each within the scatter of the next).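

In this assay, the (ethoxycarbonyl)amino group on this aromatic carbon, opposite the ring oxygen, can give way to the smaller chloromethyl, which has no hydrogen-bond donor or acceptor, and the step reads no change at the digits printed from compound 2 to compound 3 (within the scatter). Measured against (ethoxycarbonyl)methoxy, chloromethyl gives a number 21 percentage points higher from compound 1 to compound 3 (beyond the scatter), so among these three compounds it is compound 1 that stands apart, while two quite different groups read alike. Nothing measured here explains why these groups compare as they do.

Going by these compounds, each reading comes from a single concentration and shows only modest inhibition, so how far this position can raise inhibition stays unknown. On these data alone, it is also open how an amine, a carboxylic acid or a plain methyl would read here, and so whether the chlorine of chloromethyl matters.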